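Swapping pyridin-2-yl for thiophen-2-yl on the shared core

The source may report more compounds than this note shows. Statements on the series, on what has been measured and on what is new or still open speak of the compounds shown alone.

Four compounds are built on one shared core. For the measured compounds named here, compound 2 `Oc1ccc(-c2cc(-c3cccc(Cl)c3)nc(-c3ccccn3)c2)cc1` is the only one with a number: in an assay on isolated protein for inhibition of DNA topoisomerase 1 (Homo sapiens), with a stated time of 30 min, tested at 20 uM (a higher number here means a stronger effect of the compound at the concentration tested, a lower number a weaker effect), compound 2 gives 0%. Compound 1 `Oc1ccc(-c2cc(-c3ccccn3)nc(-c3ccccc3Cl)c2)cc1` gives "not determined" (no result reported) in this assay, and compound 3 `Oc1cccc(-c2cc(-c3ccc(Cl)cc3)nc(-c3cccs3)c2)c1` gives "not determined" (no result reported) in this assay, so compound 2 stands alone and cannot be ranked against them. Compound 4 `Oc1ccc(-c2cc(-c3cccc(Cl)c3)nc(-c3cccs3)c2)cc1` has not yet been measured. It differs from compound 2 in one place: thiophen-2-yl in place of pyridin-2-yl on an aromatic carbon. Going by the values given here, no measured pair shows this change, so its size in this assay is unknown. Because compound 2 gives 0%, the step is expected to stay within the scatter: a number 5 percentage points higher from compound 2 to compound 4 (within the scatter). Compound 4 is therefore estimated at 5% in this assay, with a range from 0% to 20%.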

Compound 4, a percentage reported as inhibition, at one concentration (the size of the read-out at that concentration, not a potency): 0%
Estimate against measurement, compound 4: 5 percentage points above; the measured number falls inside the stated range.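

For the compounds shown here, the first pair to test this position in this assay shows no change at the digits printed from compound 2 to compound 4 (within the scatter), with thiophen-2-yl in place of pyridin-2-yl on the aromatic carbon next to the ring nitrogen. Going by these compounds alone, neither of these two aromatic rings gives a read-out at the one concentration tested, so the pair sets no size for the change and shows only that this swap does not produce a measurable effect. On these data alone, whether an amine or a carboxylic acid on this carbon would give any read-out in this assay remains open. No measurement at hand explains the result.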